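The source may hold more compounds than are shown below. What is called first, only, known or untested is meant among the compounds shown, and "the series" means these compounds.

Series notes. The shared core carries an alkyl chain on an amine nitrogen; compound 1 `CCCCCCNc1cnc(C(=O)NCc2ccccc2)cn1` and compound 2 `CCCCCCCCNc1cnc(C(=O)NCc2ccccc2)cn1` differ only in that chain. In an ADME assay on Vero cells (Chlorocebus sabaeus) for cytotoxicity, read by microscopy, with a stated time of 6 days (a lower number here means that less compound is tolerated, a higher number that more compound is tolerated), compound 1 gives >= 100000 nM, which is a limit of the assay rather than a number. In this assay, going by the values given here, compound 2 gives 20000 nM, the only number among the two values shown. The other value, that of compound 1, sits at a limit (the limit of >= 100000 nM in this assay, at which 1 of the 2 values shown sits). Among the compounds with values here, the one measured step that bears here is an at least 5.0-fold lower number from compound 1 to compound 2 (0.69 log units; beyond the scatter), beyond the scatter. Compound 3 `CCCCCNc1cnc(C(=O)NCc2ccccc2)cn1` carries the change (hydrogen in place of propyl on a saturated chain carbon, five bonds along the chain from a nitrogen on an aromatic ring); the same difference cut one bond further out reads hexyl to propyl, so it runs opposite to the measured step. In this assay compound 3 is therefore expected to give a higher number, the expected step being a 5.0-fold higher number from compound 2 to compound 3 (0.70 log units; beyond the scatter), quite possibly ending at the limit. The estimate for compound 3 in this assay is 100000 nM, within 40000 nM to 300000 nM.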

Compound 3, minimum cytotoxic concentration: > 100000 nM
Compound 3 was reported as a limit; the forecaster's own chance of this, stated with the estimate: 70%; the middle value lies on the limit itself.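

In this assay, hydrogen in place of propyl on a saturated chain carbon, five bonds along the chain from a nitrogen on an aromatic ring, gives an at least 5.0-fold higher number from compound 2 to compound 3 (0.69 log units; beyond the scatter), so this cut in the chain takes the series back to the top of the tested range. The value of compound 3 is a limit and not a number: the limit of > 100000 nM in this assay, at which 1 of the 3 values shown sits. The value of compound 1 is also a limit, so the step between compound 1 and compound 3 cannot be read, and the two chains cannot be ordered: the limit of >= 100000 nM in this assay, at which 1 of the 3 values shown sits.

As far as these compounds go, compound 2 alone gives a number, 20000 nM, so the shape of the trend with chain length remains open. Also open, from the compounds shown here alone, are whether a longer chain lowers the number further and how a terminal amine or carboxylic acid on the chain would read in this assay.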